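Swapping the aryl urea end on a second chain variant

The source may hold more compounds than are shown below. What is called first, only, known or untested is meant among the compounds shown, and "the series" means these compounds.

Measured so far in a functional assay on NCI-H460 cells (Homo sapiens) for antiproliferative activity, read by MTT assay, with a stated time of 72 h; a lower number here means a stronger inhibitor, a higher number a weaker inhibitor:
compound 1 `CCN(CC)CCn1cnnc1-c1cc(Oc2ccc(NC(=O)Nc3ccccc3C(F)(F)F)cc2F)ccn1` gives > 50000 nM, a limit of this assay, not a number.
compound 2 `CCN(CC)CCn1cnnc1-c1cc(Oc2ccc(NC(=O)Nc3ccc(F)c(F)c3)cc2F)ccn1` gives 14900 nM.
compound 3 `CN(C)CCCn1cnnc1-c1cc(Oc2ccc(NC(=O)Nc3ccccc3C(F)(F)F)cc2F)ccn1` gives 10900 nM.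

Compound 1 sits at the limit of > 50000 nM in this assay, at which 1 of the 3 values shown sits. The change from compound 1 to compound 2 is 3,4-difluorophenyl in place of 2-(trifluoromethyl)phenyl on an amide-type nitrogen, and it gave an at least 3.3-fold lower number from compound 1 to compound 2 (0.52 log units; beyond the scatter). Compound 3 differs from compound 1 by (dimethylamino)methyl in place of diethylamino on a saturated chain carbon, two bonds along the chain from an aromatic nitrogen, giving an at least 4.5-fold lower number from compound 1 to compound 3 (0.66 log units; beyond the scatter). Compound 4 `CN(C)CCCn1cnnc1-c1cc(Oc2ccc(NC(=O)Nc3ccc(F)c(F)c3)cc2F)ccn1` has not yet been measured; it differs from compound 3 by 3,4-difluorophenyl in place of 2-(trifluoromethyl)phenyl on an amide-type nitrogen, the same change as from compound 1 to compound 2, at a place described in the same words. Because the earlier step was an at least 3.3-fold lower number from compound 1 to compound 2 (0.52 log units; beyond the scatter), a step of similar size is expected from compound 3 to compound 4, namely a 3.1-fold lower number from compound 3 to compound 4 (0.49 log units; beyond the scatter). Compound 4 is therefore estimated at 3500 nM in this assay, with a likely range from 1000 nM to 12000 nM.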

Compound 4, half-maximal inhibitory concentration: 1080 nM
The estimate for compound 4 lay 3.2-fold (0.51 log units) above the measured number, and the stated range covers the measured number.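

In this assay, the swap to 3,4-difluorophenyl carried over to the second chain in the same direction, giving a 10-fold lower number from compound 3 to compound 4 (1.00 log units; beyond the scatter). The chain change, (dimethylamino)methyl in place of diethylamino, also carried over to the compounds with the 3,4-difluorophenyl end, giving a 14-fold lower number from compound 2 to compound 4 (1.14 log units; beyond the scatter). Compound 1 stands at a limit of the assay rather than at a number, so this does not show whether the swap has the same size on both cores: the same change on two cores in this assay, an at least 3.3-fold lower number (0.52 log units; beyond the scatter) from compound 1 to compound 2 and a 10-fold lower number (1.00 log units; beyond the scatter) from compound 3 to compound 4; the limit leaves it open whether they differ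

The compounds shown leave open how a chlorophenyl end would behave on either chain. They also leave open whether a morpholine or a piperidine in place of the dimethylamino group would follow the same trend.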